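This account rests on a few compounds, and the source may have more. Where it says the series, first, only, none or still open, it means among the compounds named here.

Of the compounds shown here, three sharing one core have been measured in a functional assay on NCI-H23 cells (Homo sapiens) for inhibition, read by sulforhodamine B assay, with a stated time of 48 h; a higher number here means a weaker inhibitor of growth, a lower number a stronger inhibitor of growth. Compound 1 `Nc1cc(N)c2nc(-c3ccccc3)c(Oc3ccc(Cl)c(Cl)c3)nc2c1` gives 15500 nM. Compound 2 `COc1ccc(CNc2nc3cc(N)cc(N)c3nc2-c2ccccc2)cc1OC` gives 17000 nM, the highest of the three numbers, though its nearest neighbour is compound 1 and both lie within the scatter of each other. Compound 3 `COc1cc(CNc2nc3cc(N)cc(N)c3nc2-c2ccccc2)cc(OC)c1OC` gives 8710 nM. Among the compounds with values here, the only single change among the measured compounds is a 2.0-fold lower number from compound 2 to compound 3 (0.29 log units; within the scatter), which means the added methoxy made no difference that can be trusted.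

Compound 4 `COc1ccc(CNc2nc3cc(N)cc(N)c3nc2-c2ccccc2)cc1` is not yet measured. It differs from compound 2 by hydrogen in place of methoxy on an aromatic carbon. This is the same kind of alteration as the measured one, but in reverse: a methoxy is taken away rather than added. Since the measured addition of a methoxy, a 2.0-fold lower number from compound 2 to compound 3 (0.29 log units; within the scatter), stayed within the scatter, there is no evidence that removing one would move the number beyond it either. The expectation in this assay is therefore a change of no more than the scatter, in either direction, most likely a number close to that of compound 2.

Compound 4 is estimated to give 20000 nM, with a range from 9000 nM to 45000 nM. That estimate corresponds to an expected step of a 1.2-fold higher number from compound 2 to compound 4 (0.07 log units; within the scatter).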

Compound 4, concentration for 50% growth inhibition: 17000 nM
For compound 4 the middle estimate is 1.2-fold (0.07 log units) above the measured one, within the range that was stated.
By their numbers in this assay, from the lowest: compounds 3, 1, 2 and 4 (each within the scatter of the next).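

In this assay, replacing the 3,4-dimethoxyphenyl group with 4-methoxyphenyl brings no change at the digits printed from compound 2 to compound 4 (within the scatter) and so leaves the number where it was. The earlier step of a 2.0-fold lower number from compound 2 to compound 3 (0.29 log units; within the scatter) covered only the addition of a methoxy to this ring, whereas this result shows that taking one away, from the carbon ortho to a methoxy group and meta to a large group, also produces no change that can be trusted. With hydrogen or methoxy on this carbon, then, the read-out stays the same, and no outside measurement is available to explain why.

This says little about other groups on the same carbon, since hydrogen and methoxy are the only two compared here, and an amine, a carboxylic acid or a longer chain such as butoxy could still give a step beyond the scatter. As far as these compounds go, it also remains open whether removing the remaining methoxy as well, leaving an unsubstituted phenyl ring, would matter in this assay when the single removal did not.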